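This account rests on a few compounds, and the source may have more. Where it says the series, first, only, none or still open, it means among the compounds named here.

Of the compounds shown here, three built on one shared core have been tested in a functional assay on MCF7 cells (Homo sapiens) for inhibition, read by sulforhodamine B assay, with a stated time of 48 h, tested at 10 uM; a lower number here means less inhibition, a higher number more inhibition at the concentration tested (going by the name of the read-out). Compound 1 `Brc1cn2ccnc2c(-c2ccc3ncn(C4CCCCC4)c3c2)n1` gives 47.6%. Compound 2 `O=Cc1ccc(-c2cn3ccnc3c(-c3ccc4ncn(C5CCCCC5)c4c3)n2)cc1` gives 47.8%, and compound 3 `COc1ccccc1-c1cn2ccnc2c(-c2ccc3ncn(C4CCCCC4)c3c2)n1` gives 8.4%. Compound 2 thus holds the highest of the three numbers, though compound 1 sits within the scatter of it and only compound 3 lies clearly below: the step of a number 0.2 percentage points higher from compound 1 to compound 2 (within the scatter) is small, while a number 39.4 percentage points lower from compound 2 to compound 3 (beyond the scatter) and a number 39.2 percentage points lower from compound 1 to compound 3 (beyond the scatter) are both large drops.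

Compound 4 `FC(F)(F)c1cccc(-c2cn3ccnc3c(-c3ccc4ncn(C5CCCCC5)c4c3)n2)c1` has not yet been measured. It differs from compound 2 in one place: 3-(trifluoromethyl)phenyl in place of 4-formylphenyl on an aromatic carbon. Two kinds of measured step bear on this. Exchanging bromo for 4-formylphenyl changed little, whereas putting 2-methoxyphenyl in place of either bromo or 4-formylphenyl cut the number sharply. A further new substituent at that carbon could follow either precedent, so a downward and uncertain step a number 12.8 percentage points lower from compound 2 to compound 4 (beyond the scatter) is expected. Compound 4 is estimated to give 35%, within a range from 10% to 60%.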

Compound 4, a percentage reported as inhibition, at one concentration (the size of the read-out at that concentration, not a potency): 19.9%
Compound 4: middle estimate off by 15.1 percentage points, on the high side, and the stated range covers the measured number.
By their numbers in this assay, from the lowest: compound 3; then compound 4; then compounds 1 and 2 (each within the scatter of the next).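

Going by these compounds alone, this result shows that 2-methoxyphenyl is not the only aromatic group at this carbon that gives a clear fall: 3-(trifluoromethyl)phenyl gives a number 27.9 percentage points lower from compound 2 to compound 4 (beyond the scatter) and also a number 27.7 percentage points lower from compound 1 to compound 4 (beyond the scatter). The phenyl ring alone therefore does not set the outcome, as a number 11.5 percentage points higher from compound 3 to compound 4 (beyond the scatter) places the three phenyl-bearing compounds at three separate levels. Nothing at hand explains why these groups differ.

The three phenyl groups differ in both the substituent and its place on the ring, so the effect of each remains unseparated. Also open, going by these compounds, is how the number would respond to an amine or a carboxylic acid on that phenyl ring, or to a plain alkyl chain replacing the ring.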